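From pyridin-3-yl to pyrimidin-2-yl on an amine nitrogen

The compounds below may be only part of what the source reports. "The series", "measured", "known", "first", "only" and "open" are said of these compounds alone.

Measured so far in an ADME assay on L02 cells (Homo sapiens) for cytotoxicity, read by CCK-8 assay, with a stated time of 6 days; on this read-out higher numbers stand for weaker inhibition and lower numbers for stronger inhibition
Compound 1 `C[C@@H](Cn1ccc(-c2ccc(C#N)c(Cl)c2)n1)NC(=O)c1ccccc1` gives "not determined" (no result reported)
Compound 2 `C[C@@H](Cn1ccc(-c2ccc(C#N)c(Cl)c2)n1)Nc1cccnc1` gives > 30000 nM

Among the compounds with values here, only two compounds sharing one core have been put through this test of harm to cultured cells, and compound 1 has no result to work with. Compound 2 gives > 30000 nM in this test, and that is a limit of the assay, not a number. The whole picture so far therefore comes down to the limit of > 30000 nM in this assay, at which 1 of the 2 values shown sits, and nothing firmer.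

Compound 3 `C[C@@H](Cn1ccc(-c2ccc(C#N)c(Cl)c2)n1)Nc1ncccn1` keeps the core of compound 2 and has the change pyrimidin-2-yl in place of pyridin-3-yl on an amine nitrogen as its only difference, pyrimidin-2-yl in place of pyridin-3-yl on an amine nitrogen. Within the data shown here, no measured pair shows what such a swap does here. The expectation rests on compound 2, whose reading of > 30000 nM is a limit, so no shift beyond the usual scatter is expected and no direction can be named. The expected move is a number no higher from compound 2 to compound 3 (the limit leaves the size open) in this comparison. For compound 3 the estimated value is 30000 nM with an expected range from 12000 nM to 60000 nM in this assay when the measurement arrives.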

Compound 3, half-maximal inhibitory concentration: > 30000 nM
Compound 3: only a limit was reported (the forecaster's own chance of this, stated with the estimate: 70%); the middle value lies on the limit itself.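

No step can be read between compound 2 and compound 3 in this assay, because each reading is a limit and not a number: the limit of > 30000 nM in this assay, at which 2 of the 3 values shown sit.

The compounds shown leave open whether pyrimidin-2-yl in place of pyridin-3-yl on an amine nitrogen changes the harm to these cells at all, and at what concentration either compound would start to show it.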